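The compounds below may be only part of what the source reports. "The series", "measured", "known", "first", "only" and "open" are said of these compounds alone.

In a functional assay on SK-MEL-5 cells (Homo sapiens) for cytotoxicity (on this read-out higher numbers stand for an effect only at larger amounts of compound and lower numbers for an effect already at smaller amounts), three compounds built on the same core have been measured. Compound 1 `COc1cc(/C=C/c2ccc(C(C)C)cc2)cc(OC)c1OC` gives 11.1 uM and compound 2 `CCOc1ccc(/C=C/c2cc(OC)c(OC)c(OC)c2)cc1` gives 1.17 uM. Compound 3 `CCCOc1ccc(/C=C\c2cc(OC)c(OC)c(OC)c2)cc1` gives 1.4 uM. That places compound 3 level with compound 2, within the scatter, and clearly below compound 1 on this scale.

The next molecule, compound 4 `CCCOc1ccc(/C=C/c2cc(OC)c(OC)c(OC)c2)cc1`, keeps every atom of compound 3 and alters only the geometry of the double bond: the two compounds have the same atoms and bonds and differ only in configuration as drawn: 1 of 1 stereo elements differ; a double bond is drawn Z in compound 3 and E in compound 4. Compound 4 is therefore drawn E, as compound 1 and compound 2 are.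

Going by the values given here, only one measured step connects two close relatives, a 9.5-fold lower number from compound 1 to compound 2 (0.98 log units; beyond the scatter), where ethoxy takes the place of isopropyl. It is a sizeable step, but it concerns a group on the aromatic ring and leaves the double bond untouched, so it says nothing directly about this change. Among the compounds with values here, no pair measured so far differs in double-bond geometry alone. The closest guide is that compound 2, drawn E, shows 1.17 uM, while compound 3, drawn Z with a different chain, shows 1.4 uM, and these two values lie within the scatter. No shift beyond the scatter is therefore expected, in either direction, and the expected step is a 1.1-fold higher number from compound 3 to compound 4 (0.03 log units; within the scatter). For compound 4 the estimated value is 1.5 uM, with an expected range from 0.5 uM to 5 uM.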

Compound 4, concentration for half-maximal effect: > 25 uM
Compound 4: a limit, no number; the forecaster's own chance of this, stated with the estimate: 3%; at least 16-fold (1.22 log units) between middle value and limit.
By their numbers in this assay, from the lowest: compounds 2 and 3 (each within the scatter of the next); then compound 1. At a limit, above all of these: compound 4.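

The result for compound 4 in this assay is a limit, not a number: the limit of > 25 uM in this assay, at which 1 of the 4 values shown sits.

Even so, the geometry of the double bond clearly matters at this position, with an at least 17-fold higher number from compound 3 to compound 4 (1.25 log units; beyond the scatter), and that gap belongs to the geometry alone because no other part of the molecule changes: the fact that compounds 3 and 4 differ only in the configuration as drawn

The E compounds add a second point: the group on the ring also counts, since a single added methyl that turns ethoxy into propoxy gives an at least 21-fold higher number from compound 2 to compound 4 (1.32 log units; beyond the scatter), and propoxy in place of isopropyl gives an at least 2.2-fold higher number from compound 1 to compound 4 (0.35 log units; beyond the scatter).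

On these data alone, the true size of all three steps stays open, as each of them ends at a limit, and only the propoxy compounds form a pair that differs in geometry alone, so it is unclear whether the Z form would also give the lower number with ethoxy or isopropyl on the ring. As far as these compounds go, it is equally open how a longer chain such as butoxy, or an amine in place of the propoxy group, would behave in either geometry.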